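Ether side-chain variation and mouse oral exposure

The source may hold more compounds than are shown below. What is called first, only, known or untested is meant among the compounds shown, and "the series" means these compounds.

Measured compounds:
compound 1, `NCCOc1ccc([C@H]2CC[C@]3(CC2)OOC2(O3)C3CC4CC(C3)CC2C4)cc1`: 1370 ng.h/mL
compound 2, `CC(C)(O)CN1CCC(Oc2ccc([C@H]3CC[C@]4(CC3)OOC3(O4)C4CC5CC(C4)CC3C5)cc2)CC1`: 14200 ng.h/mL
compound 3, `N[C@H]1CC[C@@H](Oc2ccc([C@H]3CC[C@]4(CC3)OOC3(O4)C4CC5CC(C4)CC3C5)cc2)CC1`: 13400 ng.h/mL

In an ADME assay on the whole organism (strain FVB) for pharmacokinetics, with Mus musculus as the target, read by LC-MS, at a dose of 30 mg/kg by the oral route (a higher number here means more compound in the circulation at the dose given, a lower number less compound in the circulation), compound 3 gives 13400 ng.h/mL, the second highest of the three numbers; the gap to compound 2 is within the scatter (a 1.1-fold lower number from compound 2 to compound 3 (0.03 log units; within the scatter)), whereas compound 1 sits far lower (a 9.8-fold higher number from compound 1 to compound 3 (0.99 log units; beyond the scatter)). Compound 4, `c1cc([C@H]2CC[C@]3(CC2)OOC2(O3)C3CC4CC(C3)CC2C4)ccc1OCC1CCNCC1`, differs from compound 3 by (piperidin-4-yl)methyl in place of 4-aminocyclohexyl on an oxygen on an aromatic ring.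

Among the measured compounds shown here, two steps bear on this. Both replacements of 2-aminoethyl by a six-membered ring carrying a nitrogen raised exposure strongly (a 10-fold higher number from compound 1 to compound 2 (1.02 log units; beyond the scatter), a 9.8-fold higher number from compound 1 to compound 3 (0.99 log units; beyond the scatter)), while exchanging one such ring group for another changed nothing beyond the scatter (a 1.1-fold lower number from compound 2 to compound 3 (0.03 log units; within the scatter)). Compound 4 again carries a six-membered non-aromatic ring with a single nitrogen, so no step beyond the scatter is expected: a 1.2-fold lower number from compound 3 to compound 4 (0.09 log units; within the scatter). Compound 4 is therefore estimated at 11000 ng.h/mL, expected between 4500 ng.h/mL and 27000 ng.h/mL.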

Compound 4, area under the concentration-time curve: 4040 ng.h/mL
For compound 4 the middle estimate is 2.7-fold (0.44 log units) above the measured one; measured number below the stated range.
By their numbers in this assay, from the lowest: compound 1; then compound 4; then compounds 3 and 2 (each within the scatter of the next).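

In this assay, the groups on this oxygen are not interchangeable, even with the same atoms joined differently (a 3.3-fold lower number from compound 3 to compound 4 (0.52 log units; beyond the scatter)) and against the substituted piperidine (a 3.5-fold lower number from compound 2 to compound 4 (0.55 log units; beyond the scatter)). (Piperidin-4-yl)methyl still improves on the open chain (a 2.9-fold higher number from compound 1 to compound 4 (0.47 log units; beyond the scatter)), so a six-membered non-aromatic ring with one nitrogen does not by itself give the level of compound 2 or compound 3. No available data explain the difference between these groups.

Going by these compounds, it remains open whether the extra carbon link or the nitrogen's place in the ring matters more. Unsubstituted piperidin-4-yl directly on the oxygen would help separate the two.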